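The source may hold more compounds than are shown below. What is called first, only, known or untested is meant among the compounds shown, and "the series" means these compounds.

Within the data shown here, in an ADME assay on HepG2 2.2.15 cells (Homo sapiens) for cytotoxicity, read by CCK-8 assay, with a stated time of 8 days (a lower number here means that less compound is tolerated, a higher number that more compound is tolerated), compound 1 `CCOc1ccc(-c2cc(NC(=O)c3ccc(OC)cc3O)c[nH]c2=O)cc1` gives 69600 nM as the highest of the three numbers measured so far. Compound 2 `CCOc1ccc(-c2cc(NC(=O)c3ccc(Cl)cc3O)c[nH]c2=O)cc1` stands at 28600 nM and compound 3 `CCOc1ccc(-c2cc(NC(=O)c3ccc(C(F)(F)F)cc3O)c[nH]c2=O)cc1` stands at 22200 nM in the same read-out. Compound 4 `COc1ccc(C(=O)Nc2c[nH]c(=O)c(-c3cc(C)ccc3C)c2)c(O)c1` keeps the methoxy group of compound 1 and differs elsewhere, with 2,5-dimethylphenyl in place of 4-ethoxyphenyl on an aromatic carbon as the whole change.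

The measured steps bear on this only indirectly: none touches the 4-ethoxyphenyl group. Replacing the methoxy gave a 2.4-fold lower number from compound 1 to compound 2 (0.39 log units; beyond the scatter) with chloro and a 3.1-fold lower number from compound 1 to compound 3 (0.50 log units; beyond the scatter) with trifluoromethyl, both modest, while a 1.3-fold lower number from compound 2 to compound 3 (0.11 log units; within the scatter) stays within the scatter. No change at the place now altered has been measured. With compound 1 at 69600 nM as the top of the three, a modest step to a lower number in this assay is expected, about the size of a 2.4-fold lower number from compound 1 to compound 2 (0.39 log units; beyond the scatter) or a little smaller. The estimate is thus a 2.1-fold lower number from compound 1 to compound 4 (0.32 log units; beyond the scatter) as the expected step. For compound 4 the estimated value is 33000 nM with an expected range of 13000 nM to 85000 nM in this read-out.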

Compound 4, half-maximal cytotoxic concentration: 50400 nM
The estimate for compound 4 lay 1.5-fold (0.18 log units) below the measured number; low and high end bracket the measured number.
By their numbers in this assay, from the lowest: compounds 3, 2, 4 and 1 (each within the scatter of the next, the first and the last beyond it).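

In this assay, among these compounds, the first measured change at this position, on an aromatic carbon of a six-membered aromatic ring with 1 nitrogen, gives a 1.4-fold lower number from compound 1 to compound 4 (0.14 log units; within the scatter) on going from 4-ethoxyphenyl to 2,5-dimethylphenyl. The read-out therefore does not separate these two groups, even though the entering group has 0 hydrogen-bond acceptors and the leaving group has 1, and the ring carries its substituents in a different pattern. Nothing available gives a reason for this result.

As far as these compounds go, it remains open whether an amine, a carboxylic acid or a longer chain on this ring would likewise stay within the scatter. Also open, from the compounds shown here alone, is how 2,5-dimethylphenyl would read when paired with the chloro of compound 2 or the trifluoromethyl of compound 3.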